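Replacing the dimethylated acrylamide of compound 1 with a piperidinylpropenamide

This account rests on a few compounds, and the source may have more. Where it says the series, first, only, none or still open, it means among the compounds named here.

Compound 1 `COc1cc2ncnc(N3CCc4ccccc43)c2cc1NC(=O)C=C(C)C` is the reference point of this series. In a functional assay on MCF7 cells (Homo sapiens) for antiproliferative activity, read by MTT assay, with a stated time of 72 h (on this read-out lower numbers stand for stronger inhibition and higher numbers for weaker inhibition), compound 1 gives 6390 nM, the second highest of the three numbers recorded. Its nearest neighbour is compound 2 `C=CC(=O)Nc1cc2c(N3CCc4ccccc43)ncnc2cc1O[C@@H]1CCOC1`, which in this assay gives 5950 nM, within the scatter of compound 1. The furthest is compound 3 `CC(C)=CC(=O)Nc1cc2c(N3CCc4ccccc43)ncnc2cc1O[C@@H]1CCOC1`, which in this assay gives 15700 nM; the step of a 2.5-fold higher number from compound 1 to compound 3 (0.39 log units; beyond the scatter) exchanges only the group on the oxygen on the aromatic ring.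

Compound 4 `COc1cc2ncnc(N3CCc4ccccc43)c2cc1NC(=O)/C=C/CN1CCCCC1` keeps the methoxy of compound 1 and alters the acrylamide: 3-(piperidin-1-yl)prop-1-en-1-yl in place of 2-methylprop-1-en-1-yl on a carbonyl carbon. Going by the values given here, the one measured step at that same position is a 2.6-fold higher number from compound 2 to compound 3 (0.42 log units; beyond the scatter), where adding two methyl groups to the vinyl raised the number. Compound 4 removes those methyl groups and in their place carries a piperidinylmethyl chain, a change of a different kind, so that step bears on the present one only as a hint that the substitution pattern at the carbonyl carbon matters at a modest scale. A modest step downward, or none beyond the scatter, is therefore expected: a 1.8-fold lower number from compound 1 to compound 4 (0.26 log units; within the scatter). Compound 4 is estimated to give 3500 nM in this assay, with a range from 1000 nM to 12000 nM.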

Compound 4, half-maximal inhibitory concentration: 1680 nM
For compound 4 the middle estimate is 2.1-fold (0.32 log units) above the measured one; the range from low to high includes it.
By their numbers in this assay, from the lowest: compound 4; then compounds 2 and 1 (each within the scatter of the next); then compound 3.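

In this assay, going by these compounds alone, exchanging 2-methylprop-1-en-1-yl for 3-(piperidin-1-yl)prop-1-en-1-yl on the carbonyl carbon gives a 3.8-fold lower number from compound 1 to compound 4 (0.58 log units; beyond the scatter) and so shows that this position can also lower the number, whereas the only earlier step there, a 2.6-fold higher number from compound 2 to compound 3 (0.42 log units; beyond the scatter) in a different setting, ran upward. The entering group is the larger of the two and brings a nitrogen and a six-membered non-aromatic ring, so the series now shows that this position accepts such a chain on the methoxy compound without any loss in this read-out. Nothing measured here explains the lower number, and the size of the step is all that can be stated.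

The compounds shown leave open whether the piperidine ring itself matters or whether another amine on the same chain, such as a dimethylamine or a morpholine, would give a similar number. They also leave open whether 3-(piperidin-1-yl)prop-1-en-1-yl would lower the number to the same extent on the oxolan-3-yl compounds, where the oxygen on the aromatic ring carries that group in place of methyl.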